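The compounds below may be only part of what the source reports. "The series", "measured", "known", "first", "only" and "open" are said of these compounds alone.

Measured in an ADME assay on HEK293 cells (Homo sapiens) for cytotoxicity, read by resazurin assay, with a stated time of 48 h; a higher number here means that more compound is tolerated, a lower number that less compound is tolerated:
- compound 1 `O=S(=O)(Nc1ccc2oc(-c3ccccc3)nc2c1)c1cccc(F)c1`: 68000 nM
- compound 2 `O=S(=O)(Nc1ccc2oc(-c3ccccc3)nc2c1)c1ccc(Cl)cc1`: 65000 nM
- compound 3 `O=S(=O)(Nc1ccc2oc(-c3ccccc3)nc2c1)c1cccs1`: 97000 nM

Within the data shown here, compound 3 stands level with the other two, since all three differ only in the group on the sulfonyl sulfur and no step among them leaves the scatter. The next compound is compound 4 `CCc1ccc(S(=O)(=O)Nc2ccc3oc(-c4ccccc4)nc3c2)cc1`, with 4-ethylphenyl in place of thiophen-2-yl on a sulfonyl sulfur.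

Among the measured compounds shown here, three measured steps bear on this change: a 1.0-fold lower number from compound 1 to compound 2 (0.02 log units; within the scatter), a 1.4-fold higher number from compound 1 to compound 3 (0.15 log units; within the scatter) and a 1.5-fold higher number from compound 2 to compound 3 (0.17 log units; within the scatter). The last two exchange a substituted phenyl and thiophen-2-yl, as this change does, though in the opposite direction. For the measured compounds named here, no measured compound carries 4-ethylphenyl. No step beyond the scatter is therefore expected in this assay, and any direction is tentative. The estimate is placed close to compound 1 at 68000 nM and compound 2 at 65000 nM, the two measured compounds with a substituted phenyl on the sulfonyl sulfur. The expected step is a 1.4-fold lower number from compound 3 to compound 4 (0.14 log units; within the scatter). For compound 4 the estimated value is 70000 nM, with an expected range of 35000 nM to 120000 nM.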

Compound 4, half-maximal cytotoxic concentration: 81000 nM
Beside the measured number, compound 4's estimate is 1.2-fold (0.06 log units) below it; low and high end bracket the measured number.
By their numbers in this assay, from the lowest: compounds 2, 1, 4 and 3 (each within the scatter of the next).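

In this assay, 4-ethylphenyl on the sulfonyl sulfur, an all-carbon group with more heavy atoms than thiophen-2-yl, stays level with the earlier groups (a 1.2-fold lower number from compound 3 to compound 4 (0.08 log units; within the scatter)), and the same holds against 3-fluorophenyl (a 1.2-fold higher number from compound 1 to compound 4 (0.08 log units; within the scatter)) and for ethyl in place of chloro on an aromatic carbon (a 1.2-fold higher number from compound 2 to compound 4 (0.10 log units; within the scatter)). An alkyl-bearing phenyl thus joins the halogen-bearing phenyls and thiophen-2-yl, and no step among these four compounds leaves the scatter. No measured evidence bears on why this position stays so flat across these groups.

On these data alone, whether an amine, a carboxylic acid or a longer chain on the sulfonyl sulfur would give a step beyond the scatter remains open. Also open, as far as these compounds go, is whether a change elsewhere on the shared core would do so.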